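The source may report more compounds than this note shows. Statements on the series, on what has been measured and on what is new or still open speak of the compounds shown alone.

Measured so far in a functional assay on BT-549 cells (Homo sapiens) for inhibition; a higher number here means a weaker inhibitor of growth, a lower number a stronger inhibitor of growth:

compound 1 `COc1cc(/C=C/C(=O)c2cccc(-n3cc(-c4ccccc4)[nH]c3=O)c2)cc(OC)c1OC` — 1930 nM
compound 2 `COc1cc(/C=C/C(=O)c2cccc(-n3cc(-c4ccccc4)[nH]c3=O)c2)ccc1O` — 2780 nM
compound 3 `COc1ccc(-c2cn(-c3cccc(C(=O)/C=C/c4ccc(O)c(OC)c4)c3)c(=O)[nH]2)cc1` — 4570 nM

Compound 2 gives the second highest of the three numbers. Its nearest neighbour is compound 1, a lower number but within the scatter; compound 3 stands further off, a higher number, yet the step of a 1.6-fold higher number from compound 2 to compound 3 (0.22 log units; within the scatter) is also within the scatter. All three measured compounds are therefore within the scatter of one another in this assay.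

Compound 4 `O=C(/C=C/c1cccc(O)c1)c1cccc(-n2cc(-c3ccccc3)[nH]c2=O)c1` has not yet been measured. It differs from compound 2 as follows: 3-hydroxyphenyl in place of 4-hydroxy-3-methoxyphenyl on a double-bonded chain carbon bound to a double-bonded chain carbon. Going by the values given here, no measured step changes this ring in this way. Among the compounds with values here, the only recorded step, a 1.6-fold higher number from compound 2 to compound 3 (0.22 log units; within the scatter), concerns the phenyl on the shared core and bears only indirectly on the change. Within the data shown here, compound 1 and compound 2, which differ on the same ring as the change here, show values within the scatter of each other, so this ring has tolerated variation so far.

On that basis no step beyond the scatter is expected, with a slight lean toward a higher number as a 1.3-fold higher number from compound 2 to compound 4 (0.11 log units; within the scatter). The estimate for compound 4 in this assay is 3600 nM, within the range 1500 nM to 8500 nM.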

Compound 4, concentration for 50% growth inhibition: 9320 nM
Beside the measured number, compound 4's estimate is 2.6-fold (0.41 log units) below it; measured number above the stated range.
By their numbers in this assay, from the lowest: compounds 1, 2 and 3 (each within the scatter of the next, the first and the last beyond it); then compound 4.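

In this assay, 3-hydroxyphenyl in place of 4-hydroxy-3-methoxyphenyl gives a 3.4-fold higher number from compound 2 to compound 4 (0.53 log units; beyond the scatter), the first step shown that lies beyond the scatter, so the variation this group tolerated among the earlier compounds does not extend to every replacement. The change removes the methoxy and moves the hydroxy together, and the step cannot be divided between those two edits. No available evidence accounts for the step.

From the compounds shown here alone, it remains open whether the methoxy or the place of the hydroxy carries the step, which a comparison with 4-hydroxyphenyl or 3-hydroxy-4-methoxyphenyl on the same chain carbon would help separate. Also open, going by these compounds, is how an aminophenyl or a carboxyphenyl would read out at this place.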